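From Fluoro to Acetamido in a Cell Toxicity Test

This account rests on a few compounds, and the source may have more. Where it says the series, first, only, none or still open, it means among the compounds named here.

For the measured compounds named here, in an ADME assay on HeLa cells (Homo sapiens) for cytotoxicity, read by crystal violet staining, with a stated time of 72 h (on this read-out higher numbers stand for lower toxicity in this test and lower numbers for higher toxicity in this test), compound 3 `CN(C)C(=O)c1cc(CCCOc2ccc(-c3noc(C(F)(F)F)n3)cc2F)on1` gives 20200 nM, the lowest of the three numbers measured so far. Compound 1 `CCOC(=O)c1cc(CCCOc2ccc(-c3noc(C(F)(F)F)n3)cc2F)on1` gives 60200 nM, and compound 2 `COc1cc(-c2noc(C(F)(F)F)n2)ccc1OCCCc1cc(C(=O)N(C)C)no1` gives 68000 nM. Compound 4 `CC(=O)Nc1cc(-c2noc(C(F)(F)F)n2)ccc1OCCCc1cc(C(=O)N(C)C)no1` is compound 3 with acetamido in place of fluoro on an aromatic carbon. Two measured steps end at compound 3. The first, a 3.0-fold lower number from compound 1 to compound 3 (0.47 log units; beyond the scatter), puts dimethylamino in place of ethoxy on a carbonyl carbon, so it concerns a different part of the molecule and offers little guidance here. The second, a 3.4-fold lower number from compound 2 to compound 3 (0.53 log units; beyond the scatter), puts fluoro in place of methoxy on the same aromatic carbon, so it is the closer guide. Read in reverse, it shows a higher number when fluoro is replaced. Going by the values given here, no measured compound carries acetamido, so this single comparison supports only a loose expectation. The expected change is a modest rise in the number, with an estimated 2.5-fold higher number from compound 3 to compound 4 (0.39 log units; beyond the scatter). Compound 4 is estimated at 50000 nM, within an expected range of 17000 nM to 130000 nM.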

Compound 4, half-maximal cytotoxic concentration: > 100000 nM
Compound 4 gave a limit, no number; the forecaster's own chance of this, stated with the estimate: 10%; middle value at least 2.0-fold (0.30 log units) from the limit.
By their numbers in this assay, from the lowest: compound 3; then compounds 1 and 2 (each within the scatter of the next). At a limit, above all of these: compound 4.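

In this assay, compound 4 reads only as a limit, not as a number: the limit of > 100000 nM in this assay, at which 1 of the 4 values shown sits.

Until now this aromatic carbon had carried only fluoro and methoxy, and the new result shows that a larger group with a hydrogen-bond donor can sit there without lowering the number, giving an at least 4.9-fold higher number from compound 3 to compound 4 (0.69 log units; beyond the scatter). Set against methoxy on the same carbon, acetamido gives an at least 1.4-fold higher number from compound 2 to compound 4 (0.16 log units; that floor lies within the scatter), so the result separates acetamido clearly from fluoro but not from methoxy.

The compounds shown leave open how high the true number of compound 4 lies, and so how far acetamido stands from methoxy. They also leave open whether an amine, a carboxylic acid or a longer acyl chain on this aromatic carbon would give a similarly high number in this assay.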